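Tert-butyl in place of bromo: an open step

A few compounds are considered here, and "the series" means these few. Any claim that something is new, unique, unknown or untested is made for them only; others in the source may bear on it.

Among the measured compounds shown here, in a functional assay on HeLa cells (Homo sapiens) for inhibition, read by CCK-8 assay, with a stated time of 72 h, tested at 8 uM (a lower number here means less inhibition of growth, a higher number more inhibition of growth at the concentration tested), compound 2 (`Nc1ccccc1NC(=O)c1ccc(CSc2ccc(Br)cc2)cc1`) gives 38.2%, the lower of the two numbers measured so far. Compound 1 (`COc1ccc(SCc2ccc(C(=O)Nc3ccccc3N)cc2)cc1`) gives 79.7%. For the measured compounds named here, the only measured step, a number 41.5 percentage points lower from compound 1 to compound 2 (beyond the scatter), is bromo in place of methoxy on an aromatic carbon, and it is large. Compound 3 (`CC(C)(C)c1ccc(SCc2ccc(C(=O)Nc3ccccc3N)cc2)cc1`) changes that same place again, with tert-butyl in place of bromo on an aromatic carbon, para to a large group: tert-butyl in place of bromo on an aromatic carbon. Going by the values given here, the measured step shows that a change at this place can move the number strongly, but it gives no direction for tert-butyl, which no measured compound carries. No step beyond the scatter is therefore expected in this assay, though with wide uncertainty. The estimated value for compound 3 is 42%, with an expected range from 18% to 68%. This estimate means a number 3.8 percentage points higher from compound 2 to compound 3 (within the scatter).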

Compound 3, percent growth inhibition at one concentration: 40.2%
Beside the measured number, compound 3's estimate is 1.8 percentage points above it, within the range that was stated.
By their numbers in this assay, from the lowest: compounds 2 and 3 (each within the scatter of the next); then compound 1.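

In this assay tert-butyl in place of bromo, on an aromatic carbon para to a large group, gives a number 2 percentage points higher from compound 2 to compound 3 (within the scatter) and so does not separate these two groups, although bromo is a single heavy atom and tert-butyl has four carbon atoms. Tert-butyl in place of methoxy gives a number 39.5 percentage points lower from compound 1 to compound 3 (beyond the scatter) and thus repeats the large gap seen with bromo, so compound 1 now stands apart from two compounds with different groups at this place. The data offer no explanation for this difference.

From the compounds shown here alone, it remains open whether other oxygen-linked groups, such as hydroxyl or ethoxy, would match methoxy here. An amine or a carboxylic acid at this place could also fall on either side of the gap.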